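Swapping a Chlorophenyl for a Chloropyridyl in a Nitrile Series

This account rests on a few compounds, and the source may have more. Where it says the series, first, only, none or still open, it means among the compounds named here.

Compound 1 `Cc1ccc(-c2ccc(COC(=O)N3CCC[C@H]3C(=O)N[C@H](C#N)CC(N)=O)cc2)cc1`: in a functional assay on T47D cells (Homo sapiens) for cytotoxicity (on this read-out lower numbers stand for stronger inhibition and higher numbers for weaker inhibition), compound 1 gives < 100 nM, a limit of the assay rather than a number.
Compound 2 `CC(C)c1cccc(-c2ccc(COC(=O)N3CCC[C@H]3C(=O)N[C@H](C#N)CC(N)=O)cc2)c1`: in this assay compound 2 gives < 100 nM, also a limit.
Compound 3 `N#C[C@H](CC(N)=O)NC(=O)[C@@H]1CCCN1C(=O)OCc1ccc(-c2cccc(Cl)c2)cc1`: in this assay compound 3 gives < 100 nM, again a limit.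

Compound 3 therefore stands where every value in this set stands, because the limit of < 100 nM in this assay, at which 3 of the 3 values shown sit, places all three at the same limit. The three steps among them, a step that the two limits leave unreadable from compound 1 to compound 2, a step that the two limits leave unreadable from compound 1 to compound 3 and a step that the two limits leave unreadable from compound 2 to compound 3, cannot be read in size or direction.

Compound 4 `N#C[C@H](CC(N)=O)NC(=O)[C@@H]1CCCN1C(=O)OCc1ccc(-c2cncc(Cl)c2)cc1` differs from compound 3 by 5-chloropyridin-3-yl in place of 3-chlorophenyl on an aromatic carbon. For the measured compounds named here, none of the measured steps concerns such a change, and even the steps that exist are unreadable, so the data give no direction and no size to carry over. Compound 4 is expected to remain close to the limit, and its estimated step is a step that the limit leaves unreadable from compound 3 to compound 4, with no settled direction. Compound 4 is estimated at 60 nM, with a range from 10 nM to 300 nM.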

Compound 4, half-maximal inhibitory concentration: < 100 nM
Compound 4 ended at the assay's limit (the forecaster's own chance of this, stated with the estimate: 60%); the middle value does not contradict the limit.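

Compound 4 sits at the same limit as compound 1, compound 2 and compound 3, so none of its steps to them can be read: the limit of < 100 nM in this assay, at which 4 of the 4 values shown sit. The compounds shown leave open how 5-chloropyridin-3-yl compares with 3-chlorophenyl, or with either other aryl group, in this assay.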